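Amino for dimethylamino on the pendant phenyl

The source may hold more compounds than are shown below. What is called first, only, known or untested is meant among the compounds shown, and "the series" means these compounds.

In a functional assay on KB-VIN10 cells (Homo sapiens) for inhibition, with a stated time of 72 h (a lower number here means a stronger inhibitor, a higher number a weaker inhibitor), compound 3 `COc1ccc(S(=O)(=O)N2CCc3cccc(-c4ccc(N(C)C)cc4)c32)cc1` gives 553 nM, the highest number of the three measured. Compound 1 `COc1ccc(S(=O)(=O)N2CCc3cccc(-c4ccc(O)cc4)c32)cc1` gives 123 nM and compound 2 `COc1ccc(S(=O)(=O)N2CCc3cccc(-c4ccc(F)c(F)c4)c32)cc1` gives 46 nM. The steps of a 4.5-fold higher number from compound 1 to compound 3 (0.65 log units; beyond the scatter) and a 12-fold higher number from compound 2 to compound 3 (1.08 log units; beyond the scatter) both place compound 3 behind the others, while a 2.7-fold lower number from compound 1 to compound 2 (0.43 log units; beyond the scatter) is a modest step.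

Compound 4 `COc1ccc(S(=O)(=O)N2CCc3cccc(-c4ccc(N)cc4)c32)cc1` differs from compound 3 by amino in place of dimethylamino on an aromatic carbon. The measured step that bears on it most is a 4.5-fold higher number from compound 1 to compound 3 (0.65 log units; beyond the scatter), where hydroxy gave way to dimethylamino; the entering amino, like hydroxy, carries a hydrogen-bond donor, so part of that step is expected to reverse. No measurement of amino against hydroxy exists in the series, so the expected step is held smaller than a full return to compound 1. Compound 4 is therefore expected to give 200 nM, with a range from 70 nM to 550 nM, which means an expected step of a 2.8-fold lower number from compound 3 to compound 4 (0.44 log units; beyond the scatter).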

Compound 4, half-maximal inhibitory concentration: 262 nM
For compound 4 the middle estimate is 1.3-fold (0.12 log units) below the measured one, and the stated range covers the measured number.
By their numbers in this assay, from the lowest: compound 2; then compound 1; then compound 4; then compound 3.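

In this assay, trimming dimethylamino to amino recovers only part of the ground lost at this position, a 2.1-fold lower number from compound 3 to compound 4 (0.32 log units; beyond the scatter), yet amino still trails hydroxy, a 2.1-fold higher number from compound 1 to compound 4 (0.33 log units; beyond the scatter), so a hydrogen-bond donor on this aromatic carbon does not by itself restore the level of the hydroxy compound. Neither nitrogen substituent approaches the 3,4-difluorophenyl analogue, with a 5.7-fold higher number from compound 2 to compound 4 (0.76 log units; beyond the scatter), and the order among the pendant phenyl groups now rests on four compounds only. Nothing available explains why these groups rank as they do.

Open, as far as these compounds go, is whether methylamino would fall between the amino and dimethylamino compounds, which would show how the number follows each added methyl. Also open, from the compounds shown here alone, is whether methoxy on the same carbon would track hydroxy or dimethylamino.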